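The source may hold more compounds than are shown below. What is called first, only, known or untested is meant among the compounds shown, and "the series" means these compounds.

Measured compounds:
compound 1, `Cc1cc(O)c(C(=O)/C=C/c2ccccc2)c(-c2ccc(Cl)cc2)c1C(=O)/C=C/c1ccccc1`, 4400 nM in a functional assay on MDA-MB-231 cells (Homo sapiens) for cytotoxicity, read by MTT assay, with a stated time of 24 h; on this read-out higher numbers stand for weaker inhibition and lower numbers for stronger inhibition
compound 2, `Cc1cc(O)c(C(=O)/C=C/c2ccc(Cl)cc2)c(-c2ccc(Cl)cc2)c1C(=O)/C=C/c1ccc(Cl)cc1`, 30000 nM
compound 3, `Cc1cc(O)c(C(=O)/C=C/c2ccc(Cl)cc2)c(-c2ccccc2)c1C(=O)/C=C/c1ccc(Cl)cc1`, 7900 nM

Compound 1 gives the lowest number of the three in this assay. Compound 3 lies close to compound 1, within the scatter, so no order between these two can be read. Compound 2 sits clearly higher than compound 1, beyond the scatter.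

Within the data shown here, the only step measured in one place is a 3.8-fold lower number from compound 2 to compound 3 (0.58 log units; beyond the scatter); it removes a chloro from the pendant phenyl ring while the rest of the core is unchanged, and the number falls modestly.

Compound 4, `Cc1cc(O)c(C(=O)/C=C/c2ccccc2)c(-c2ccc(Br)cc2)c1C(=O)/C=C/c1ccccc1`, differs from compound 1 by bromo in place of chloro on an aromatic carbon. It keeps the halogen at the same place on the same ring, so the step from compound 2 to compound 3 bears on it only loosely: that step shows a chloro at this position costing a modest amount, but it says nothing about trading one halogen for another. With no measured halogen-to-halogen swap in the series, the expected step is none beyond the scatter: the number for compound 4 is estimated at 4500 nM, with a range of 2000 nM to 10000 nM, which means an expected step of a 1.0-fold higher number from compound 1 to compound 4 (0.01 log units; within the scatter) from compound 1.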

Compound 4, half-maximal inhibitory concentration: 8000 nM
For compound 4 the middle estimate is 1.8-fold (0.25 log units) below the measured one, and the stated range covers the measured number.
By their numbers in this assay, from the lowest: compounds 1, 3 and 4 (each within the scatter of the next); then compound 2.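

In this assay, the step from chloro to bromo at this position gives a 1.8-fold higher number from compound 1 to compound 4 (0.26 log units; within the scatter), so no order can be read between the two halogens. Among these compounds, this is the first halogen-for-halogen exchange, and it differs in kind from the earlier 3.8-fold lower number from compound 2 to compound 3 (0.58 log units; beyond the scatter), which replaced chloro with hydrogen on a core that carries further chloro groups; the pair of compound 1 and compound 4 shows that, on the core with no such groups, the 4-chlorophenyl to 4-bromophenyl change produces no step beyond the scatter. Nothing available explains this result or gives a property of either halogen as measured.

Among the compounds shown here, it remains open whether hydrogen in place of the halogen would shift the number on the core of compound 1 as it does on the core of compound 2, since that step is known on only one core. Also open, going by these compounds, is how a group other than a halogen, such as a methoxy, an amine or a carboxylic acid, would read at this position in this assay.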